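The compounds below may be only part of what the source reports. "The series", "measured", "known", "first", "only" and "open" are said of these compounds alone.

In a functional assay for agonist activity at G protein-coupled receptor 88 (Homo sapiens), read by HTRF and cAMP accumulation (on this read-out higher numbers stand for an effect only at larger amounts of compound and lower numbers for an effect already at smaller amounts), compound 1 `CC(C)C[C@@H](N)CN(C(=O)[C@@H]1C[C@H]1c1ccccc1)c1ccc(-c2ccccc2)cc1` gives 1.8 nM, and compound 2 `N[C@@H](CC1CCCCC1)CN(C(=O)[C@@H]1C[C@H]1c1ccccc1)c1ccc(-c2ccccc2)cc1` gives 1.7 nM, a pair that differ only by a 1.1-fold lower number from compound 1 to compound 2 (0.02 log units; within the scatter). Compound 3 `N[C@H](CN(C(=O)[C@@H]1C[C@H]1c1ccccc1)c1ccc(-c2ccccc2)cc1)C1CCCCC1` gives 0.66 nM in this assay, the lowest of the three numbers: from compound 1 the step is a 2.7-fold lower number from compound 1 to compound 3 (0.44 log units; beyond the scatter), and from compound 2 it is a 2.6-fold lower number from compound 2 to compound 3 (0.41 log units; beyond the scatter), both modest but beyond the scatter.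

Compound 4 `CC(C)(N)CN(C(=O)[C@@H]1C[C@H]1c1ccccc1)c1ccc(-c2ccccc2)cc1` has not yet been measured. It differs from compound 3 by 1-amino-1-methylethyl in place of amino(cyclohexyl)methyl on a saturated chain carbon bound to an amide-type nitrogen. Among the measured compounds shown here, no measured pair removes the ring in this way, so the nearest guidance is indirect. The two steps that end at compound 3, a 2.7-fold lower number from compound 1 to compound 3 (0.44 log units; beyond the scatter) and a 2.6-fold lower number from compound 2 to compound 3 (0.41 log units; beyond the scatter), show that the group on that carbon can shift the number modestly when it is changed, while a 1.1-fold lower number from compound 1 to compound 2 (0.02 log units; within the scatter) shows that a branched chain and a ring of similar bulk gave numbers within the scatter of each other. Removing the ring altogether is a larger change than any of these, so compound 4 is expected to give a somewhat higher number than compound 3, a step of about a 4.5-fold higher number from compound 3 to compound 4 (0.66 log units; beyond the scatter) in this assay. On that basis compound 4 is estimated at 3 nM, with a range from 0.8 nM to 12 nM.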

Compound 4, half-maximal effective concentration: 1.4 nM
The estimate for compound 4 lay 2.1-fold (0.33 log units) above the measured number; measured number inside the range.
By their numbers in this assay, from the lowest: compound 3; then compounds 4, 2 and 1 (each within the scatter of the next).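

In this assay, the step to the ring-free 1-amino-1-methylethyl group, which has 4 heavy atoms where amino(cyclohexyl)methyl has 8, is only a 2.1-fold higher number from compound 3 to compound 4 (0.33 log units; beyond the scatter): at this position, the six-membered ring and the defined stereocentre of the group that leaves are not required for a number close to that of compound 3. The other two steps, a 1.2-fold lower number from compound 2 to compound 4 (0.08 log units; within the scatter) and a 1.3-fold lower number from compound 1 to compound 4 (0.11 log units; within the scatter), show that this small group stands level with both 1-amino-2-cyclohexylethyl and 1-amino-3-methylbutyl, and among these four compounds only amino(cyclohexyl)methyl stands apart, which means the number does not simply follow the size of the group. No measurement is at hand that explains why these groups behave in this way.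

Every compound shown carries an amine on this group, and what happens when a hydroxyl group takes its place remains open. Also open, from the compounds shown here alone, is whether the smaller aminomethyl group, without the two methyl groups of compound 4, would keep a number of this kind.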